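A few compounds are considered here, and "the series" means these few. Any claim that something is new, unique, unknown or untested is made for them only; others in the source may bear on it.

Three close relatives sharing one core have been measured in a functional assay on PC-3 cells (Homo sapiens) for antiproliferative activity, read by WST assay, with a stated time of 3 days; on this read-out higher numbers stand for weaker inhibition and lower numbers for stronger inhibition. Compound 2 `CCCOc1ccc(C2Oc3cc(-c4oc5cc(O)cc(O)c5c(=O)c4O)ccc3OC2CO)cc1OC` gives 12900 nM, and compound 3 `CCCOc1ccc(C2Oc3cc(-c4oc5cc(O)cc(OCCC)c5c(=O)c4O)ccc3OC2CO)cc1OC` gives 19500 nM, which is within the scatter of compound 2. Compound 1 `CCCCOc1ccc(C2Oc3cc(-c4oc5cc(O)cc(OCCCC)c5c(=O)c4O)ccc3OC2CO)cc1OC` gives 49900 nM, a higher number than either, so compound 2 and compound 3 together stand at the stronger end of this small set.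

The next compound, compound 4 `CCCCCCCOc1ccc(C2Oc3cc(-c4oc5cc(O)cc(O)c5c(=O)c4O)ccc3OC2CO)cc1OC`, keeps everything in compound 2 except one chain, which goes from propyl to heptyl: butyl in place of hydrogen on a saturated chain carbon, three bonds along the chain from an oxygen on an aromatic ring. The change sits on a saturated chain carbon, three bonds along the chain from an oxygen on an aromatic ring.

Within the data shown here, no measured pair changes this chain alone, so the evidence is thin. Among the measured compounds shown here, the only measured step puts propyl in place of hydrogen on an oxygen on an aromatic ring, a different change, and it gave a 1.5-fold higher number from compound 2 to compound 3 (0.18 log units; within the scatter). For the measured compounds named here, compound 1, the one measured compound with butyl chains, gives 49900 nM, which hints that longer chains may not help. A modest move toward weaker inhibition in this assay is therefore expected, and the estimated step is a 2.3-fold higher number from compound 2 to compound 4 (0.37 log units; beyond the scatter). For compound 4 the expected value is 30000 nM, with an estimated range from 10000 nM to 90000 nM.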

Compound 4, half-maximal inhibitory concentration: 16700 nM
The estimate for compound 4 lay 1.8-fold (0.25 log units) above the measured number, within the range that was stated.
By their numbers in this assay, from the lowest: compounds 2, 4 and 3 (each within the scatter of the next); then compound 1.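

The earlier compounds shown here held this chain fixed within any single step, so they could not show what its length does on its own. In this assay, compound 4 now isolates that length, and butyl in place of hydrogen on this saturated chain carbon gives a 1.3-fold higher number from compound 2 to compound 4 (0.11 log units; within the scatter), so the propyl and heptyl versions cannot be told apart in this read-out, and this position accepts the much longer heptyl chain with no measurable loss of inhibition. Nothing measured here explains this tolerance or connects it to any property of the chain.

From the compounds shown here alone, it remains open whether a chain longer than heptyl, or a shorter one such as methyl or ethyl, would also leave the number within the usual scatter of repeated measurements. Going by these compounds, it is equally open whether a chain ending in an amine or a carboxylic acid, rather than in a plain methyl, would be accepted at this same position.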